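Lengthening the side chain of compound 3

The compounds below may be only part of what the source reports. "The series", "measured", "known", "first", "only" and "open" are said of these compounds alone.

Values in a functional assay on K562 cells (Homo sapiens) for antiproliferative activity, read by MTT assay, with a stated time of 48 h (on this read-out lower numbers stand for stronger inhibition and higher numbers for weaker inhibition), so far:
- compound 1 `CCN(CC)CCn1c(N)c(-c2nc3ccccc3[nH]2)c2nc(C#N)c(C#N)nc21` gives 2490 nM
- compound 2 `CCN(CC)CCCn1c(N)c(-c2nc3ccccc3[nH]2)c2nc(C#N)c(C#N)nc21` gives 1800 nM
- compound 3 `CCN(CC)CCn1c(N)c(-c2nc3ccccc3n2C)c2nc(C#N)c(C#N)nc21` gives > 50000 nM as a limit

The reading for compound 3 is only a limit and not a number (the limit of > 50000 nM in this assay, at which 1 of the 3 values shown sits). Compound 4 `CCN(CC)CCCn1c(N)c(-c2nc3ccccc3n2C)c2nc(C#N)c(C#N)nc21` differs from compound 3 in one place, with (diethylamino)methyl in place of diethylamino on a saturated chain carbon, two bonds along the chain from an aromatic nitrogen. The same swap has been measured once, and a 1.4-fold lower number from compound 1 to compound 2 (0.14 log units; within the scatter) is the step it gave. The other measured step is large (an at least 20-fold higher number from compound 1 to compound 3 (1.30 log units; beyond the scatter)) and comes from methyl in place of hydrogen on an aromatic nitrogen. Compound 4 keeps that methyl, so nothing suggests a return towards the values of compound 1 and compound 2. No step beyond the scatter is therefore expected in this assay and the estimated change is small (a number no higher from compound 3 to compound 4 (the limit leaves the size open)). For compound 4 the expected value is 50000 nM (estimated range 20000 nM to 100000 nM).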

Compound 4, half-maximal inhibitory concentration: 3270 nM
Beside the measured number, compound 4's estimate is 15-fold (1.18 log units) above it; measured number below the stated range.
By their numbers in this assay, from the lowest: compounds 2, 1 and 4 (each within the scatter of the next). At a limit, above all of these: compound 3.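

In this assay, the swap of diethylamino for (diethylamino)methyl on a saturated chain carbon gives an at least 15-fold lower number from compound 3 to compound 4 (1.18 log units; beyond the scatter), so this position matters once the aromatic nitrogen carries a methyl, and the same change does not act alike on the two cores: the same change on two cores in this assay, a 1.4-fold lower number (0.14 log units; within the scatter) from compound 1 to compound 2 and an at least 15-fold lower number (1.18 log units; beyond the scatter) from compound 3 to compound 4, at least 11-fold (1.04 log units) apart, beyond the scatter of two such steps. The methyl is also not harmful in every setting, since with the longer chain it gives only a 1.8-fold higher number from compound 2 to compound 4 (0.26 log units; within the scatter), and the two changes therefore depend on each other: the same change on two cores in this assay, an at least 20-fold higher number (1.30 log units; beyond the scatter) from compound 1 to compound 3 and a 1.8-fold higher number (0.26 log units; within the scatter) from compound 2 to compound 4, at least 11-fold (1.04 log units) apart, beyond the scatter of two such steps. On these data alone, the reading of > 50000 nM for compound 3 is a limit and not a number, so the full size of that first step stays unknown.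

As far as these compounds go, whether a chain longer than 3-(diethylamino)propyl would keep the value of compound 4 remains open. So does the effect of a piperidine in place of the diethylamino end, or of an ethyl in place of the methyl on the aromatic nitrogen.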